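The source may report more compounds than this note shows. Statements on the series, on what has been measured and on what is new or still open speak of the compounds shown alone.

Series notes, thioether-linked quinazoline-type anilines, all carrying the same 4-(trifluoromethyl)benzyl thioether; read in a functional assay on PC-3 cells (Homo sapiens) for cytotoxicity, read by MTT assay, with a stated time of 72 h; a higher number here means a weaker inhibitor, a lower number a stronger inhibitor.

Compound 1 `COc1ccccc1Nc1nc(SCc2ccc(C(F)(F)F)cc2)nc2ccccc12` gives 14100 nM in this assay. Compound 2 `FC(F)(F)c1ccc(CSc2nc(Nc3ccc(Cl)cc3)c3ccccc3n2)cc1` gives 7110 nM, and compound 3 `O=[N+]([O-])c1ccc(Nc2nc(SCc3ccc(C(F)(F)F)cc3)nc3ccccc23)cc1` gives 7900 nM. Compound 1 holds the highest of the three numbers; the step to compound 2 is a 2.0-fold lower number from compound 1 to compound 2 (0.30 log units; within the scatter), and that to compound 3 is a 1.8-fold lower number from compound 1 to compound 3 (0.25 log units; within the scatter), so all three sit within the scatter of one another. Likewise a 1.1-fold higher number from compound 2 to compound 3 (0.05 log units; within the scatter) shows no separation between compound 2 and compound 3.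

Compound 4 `COc1ccc(Nc2nc(SCc3ccc(C(F)(F)F)cc3)nc3ccccc23)c(OC)c1` is not yet measured. It differs from compound 1 by methoxy in place of hydrogen on an aromatic carbon. Within the data shown here, none of the measured steps probes this change directly: the two steps from compound 1 replace the whole 2-methoxyphenyl rather than adding to it, and the step from compound 2 to compound 3 exchanges nitro for chloro. What they show is that three different aryl groups on the nitrogen left this assay unmoved beyond the scatter. The expectation for compound 4 is therefore a step of a 1.2-fold lower number from compound 1 to compound 4 (0.07 log units; within the scatter), that is, none beyond the scatter. Compound 4 is estimated at 12000 nM, with a range of 5000 nM to 30000 nM.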

Compound 4, half-maximal inhibitory concentration: 32500 nM
Compound 4: middle estimate off by 2.7-fold (0.43 log units), on the low side, outside the stated range (above it).
By their numbers in this assay, from the lowest: compounds 2, 3 and 1 (each within the scatter of the next); then compound 4.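

In this assay, among these compounds, the added methoxy gives a 2.3-fold higher number from compound 1 to compound 4 (0.36 log units; beyond the scatter), the first single-group change to lie beyond the scatter, so this carbon, para to the large group and meta to the existing methoxy, is not silent to substitution. The 2,4-dimethoxyphenyl group also separates from both other aryl groups, with a 4.1-fold higher number from compound 3 to compound 4 (0.61 log units; beyond the scatter) and a 4.6-fold higher number from compound 2 to compound 4 (0.66 log units; beyond the scatter); the 2-methoxyphenyl, 4-chlorophenyl and 4-nitrophenyl groups could not be told apart, so the aryl group on the nitrogen does matter in this assay, though all three new steps are modest and rest on compound 4 alone. Nothing available here bears on why the added methoxy moves the number in this direction.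

As far as these compounds go, whether the step belongs to methoxy specifically or to any group on this carbon remains open; a hydroxy, a fluoro or an amine in the same place would begin to separate the two. Also open, from the compounds shown here alone, is whether the step needs the existing methoxy, which a compound carrying only the new methoxy on this ring would address.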